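Trifluoromethyl in Place of Methyl on a Shared Core

The compounds below may be only part of what the source reports. "The series", "measured", "known", "first", "only" and "open" are said of these compounds alone.

Compound 3 `Cc1ccc2nc(C(=O)Nc3c(F)cc(-c4cccc(F)c4)cc3F)c(C)c(C(=O)O)c2c1` gives 15.2% in a functional assay on Hep 3B2 cells (Homo sapiens) for antiproliferative activity, read by MTT assay, with a stated time of 24 h, tested at 0.41 ug/mL; a lower number here means a weaker effect, a higher number a stronger effect of the compound at the concentration tested. Compound 1 `Cc1ccc2nc(C(=O)Nc3c(F)cc(-c4cccc(F)c4)cc3F)c(C)c(O)c2c1` gives 5.25%, a gap to compound 3 that lies within the usual scatter of the measurement, while compound 2 `CCOc1ccc2nc(C(=O)Nc3c(F)cc(-c4cccc(F)c4)cc3F)c(C)c(O)c2c1` gives 0.26%, a gap that lies beyond it. Compound 4 `Cc1c(C(=O)Nc2c(F)cc(-c3cccc(F)c3)cc2F)nc2ccc(C(F)(F)F)cc2c1C(=O)O` differs from compound 3 only by trifluoromethyl in place of methyl on an aromatic carbon. Going by the values given here, no measured pair changes methyl into trifluoromethyl. The nearest comparison is a number 5 percentage points lower from compound 1 to compound 2 (within the scatter), where another group replaced the methyl on an aromatic carbon; a number 10 percentage points higher from compound 1 to compound 3 (within the scatter) concerns a different part of the molecule. Among the compounds with values here, since the one measured exchange of that methyl stayed within the scatter, the expected step is a number 0.2 percentage points lower from compound 3 to compound 4 (within the scatter), again within the scatter. Compound 4 is therefore estimated to give 15%, within a range from 0% to 30%.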

Compound 4, a percentage reported as inhibition, at one concentration (the size of the read-out at that concentration, not a potency): 6.42%
For compound 4 the middle estimate is 8.6 percentage points above the measured one; the range from low to high includes it.
By their numbers in this assay, from the lowest: compounds 2, 1, 4 and 3 (each within the scatter of the next, the first and the last beyond it).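

In this assay, trifluoromethyl in place of methyl on this aromatic carbon, with the carboxy group kept, gives a number 8.8 percentage points lower from compound 3 to compound 4 (within the scatter) and so adds a second exchange of this methyl that stays within the scatter, after ethoxy with the hydroxy group in place. Nothing measured alongside these numbers bears on this result. On these data alone, whether an amine or a longer chain on this carbon would move the number beyond the scatter stays open. So does whether trifluoromethyl would give a similar step with hydroxy in place of the carboxy group.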